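The source may report more compounds than this note shows. Statements on the series, on what has been measured and on what is new or still open speak of the compounds shown alone.

Compound 3 `C[C@H](NC(=O)c1cc(C(F)(F)F)cc2c1N(Cc1ccc(C(F)(F)F)cc1)CC2)c1ccc(C(=O)O)cc1` gives 3 nM in a functional assay on HEK293 cells for antagonist activity at prostaglandin E2 receptor EP4 subtype (Homo sapiens), read by scintillation proximity assay and cAMP accumulation; a lower number here means a stronger inhibitor, a higher number a weaker inhibitor. Among the three compounds measured so far, compound 3 carries the highest number: compound 2 `C[C@H](NC(=O)c1cc(Cl)cc2c1N(Cc1ccc(C(F)(F)F)cc1)CC2)c1ccc(C(=O)O)cc1` gives 2.2 nM, a gap that lies within the scatter, while compound 1 `C[C@H](NC(=O)c1cccc2c1N(Cc1ccc(Cl)c(Cl)c1)CC2)c1ccc(C(=O)O)cc1` gives 1.1 nM, a gap beyond the scatter. Compound 4 `C[C@H](NC(=O)c1cc(F)cc2c1N(Cc1ccc(C(F)(F)F)cc1)CC2)c1ccc(C(=O)O)cc1` differs from compound 3 in one place: fluoro in place of trifluoromethyl on an aromatic carbon. Among the measured compounds shown here, only one measured step touches this position, the exchange of chloro for trifluoromethyl, which gave a 1.4-fold higher number from compound 2 to compound 3 (0.13 log units; within the scatter). For the measured compounds named here, no compound with fluoro at this carbon has been measured, so the size of the new step is not settled by the data. Because a 1.4-fold higher number from compound 2 to compound 3 (0.13 log units; within the scatter) stayed within the scatter, the expectation for compound 4 is a step of a 1.3-fold lower number from compound 3 to compound 4 (0.10 log units; within the scatter) that does not clearly leave the scatter either. Compound 4 is therefore estimated at 2.4 nM in this assay, with a likely range from 1.1 nM to 5.5 nM.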

Compound 4, half-maximal inhibitory concentration: 2.1 nM
Compound 4: the middle estimate sits 1.1-fold (0.06 log units) above what was measured; low and high end bracket the measured number.
By their numbers in this assay, from the lowest: compounds 1, 4, 2 and 3 (each within the scatter of the next, the first and the last beyond it).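

In this assay, fluoro in place of trifluoromethyl gives a 1.4-fold lower number from compound 3 to compound 4 (0.15 log units; within the scatter), and fluoro in place of chloro gives a 1.0-fold lower number from compound 2 to compound 4 (0.02 log units; within the scatter). This carbon, para to a fused ring, now carries three different groups, and every exchange among them stays within the scatter, so the series shows no preference among chloro, fluoro and trifluoromethyl here, even though trifluoromethyl has more heavy atoms than fluoro. No evidence is available on why the three groups read alike.

Still open, on these data alone, is whether this tolerance extends beyond these halogen-bearing groups, for example to an amine, a hydroxyl or a carboxylic acid on the same carbon. Also open, as far as these compounds go, is how plain hydrogen here compares, since compound 1 has hydrogen at this carbon but also differs from compound 2 in a second place.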